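A sulfonyl group enters compound 1

A few compounds are considered here, and "the series" means these few. Any claim that something is new, unique, unknown or untested is made for them only; others in the source may bear on it.

compound 1 `Cc1nc2c(Sc3ccc(Cl)cc3)cc(Cl)cn2c1[N+](=O)[O-]`: > 7800 nM
compound 2 `Cc1cc(Sc2ccc(Cl)cc2)c2nc(CS(=O)(=O)c3ccccc3)c([N+](=O)[O-])n2c1`: > 62500 nM
compound 3 `O=[N+]([O-])c1c(CS(=O)(=O)c2ccccc2)nc2c(Sc3ccc(Cl)cc3)cc(C(F)(F)F)cn12`: > 7800 nM

In an ADME assay on HepG2 cells (Homo sapiens) for cytotoxicity, read by MTT assay, with a stated time of 72 h (on this read-out lower numbers stand for higher toxicity in this test and higher numbers for lower toxicity in this test), compound 1 gives > 7800 nM, which is a limit and not a number. It stands at the limit of > 7800 nM in this assay, at which 2 of the 3 values shown sit. None of the three compounds has yet given a true number.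

Compound 4 `O=[N+]([O-])c1c(CS(=O)(=O)c2cccnc2)nc2c(Sc3ccc(Cl)cc3)cc(Cl)cn12` has not been measured. It differs from compound 1 by (pyridin-3-yl)sulfonyl in place of hydrogen on a saturated chain carbon bound to an aromatic carbon.

Among the compounds with values here, only one measured step exists, a step that the two limits leave unreadable from compound 2 to compound 3, and it is a different change: trifluoromethyl in place of methyl on an aromatic carbon. It offers no size to carry over. More useful are the two compounds that also have a sulfonyl group on a saturated chain carbon bound to an aromatic carbon, though with an all-carbon ring in place of the pyridine. Compound 2 gives > 62500 nM, also a limit. Compound 3 gives > 7800 nM, again a limit.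

On that basis, no clear rise in toxicity is expected, and another limit is the likeliest result. The expected step runs a step that the limit leaves unreadable from compound 1 to compound 4, towards lower toxicity if it can be read at all. For compound 4 the estimate is 20000 nM, with an expected range of 7800 nM to 62500 nM.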

Compound 4, half-maximal cytotoxic concentration: > 31200 nM
Compound 4 gave a limit, no number; the forecaster's own chance of this, stated with the estimate: 75%; middle value at least 1.5-fold (0.19 log units) away from the limit.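

In this assay compound 4 gives > 31200 nM, which is a limit and not a number. Compound 1 also gives only a limit, and the step from compound 1 to compound 4 cannot be read. The compounds shown leave open whether adding (pyridin-3-yl)sulfonyl changes toxicity at all: none of them has given a true number.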